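Swapping the aryl ester of a diterpenoid lactone

A few compounds are considered here, and "the series" means these few. Any claim that something is new, unique, unknown or untested is made for them only; others in the source may bear on it.

Compound 1 `C=C1C(=O)[C@@]23C(=O)OC[C@]4([C@@H](OC(C)=O)CCC(C)(C)[C@H]4C=O)[C@@H]2CC[C@H]1[C@H]3OC(=O)c1ccc(C(F)(F)F)cc1` carries an ester built from a 4-(trifluoromethyl)phenyl group. Within the data shown here, in a functional assay on K562 cells (Homo sapiens) for inhibition, read by MTT assay (on this read-out lower numbers stand for stronger inhibition and higher numbers for weaker inhibition), compound 1 gives 3150 nM, the highest of the three numbers measured so far, which on this read-out means the weakest inhibition. Compound 2 `C=C1C(=O)[C@@]23C(=O)OC[C@]4([C@@H](OC(C)=O)CCC(C)(C)[C@H]4C=O)[C@@H]2CC[C@H]1[C@H]3OC(C)=O` gives 1740 nM, and compound 3 `C=C1C(=O)[C@@]23C(=O)OC[C@]4([C@@H](OC(C)=O)CCC(C)(C)[C@H]4C=O)[C@@H]2CC[C@H]1[C@H]3OC(=O)c1ccc(C)cc1` gives 1310 nM.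

Compound 4 `C=C1C(=O)[C@@]23C(=O)OC[C@]4([C@@H](OC(C)=O)CCC(C)(C)[C@H]4C=O)[C@@H]2CC[C@H]1[C@H]3OC(=O)c1ccccc1Cl` differs from compound 1 at the same ester: 2-chlorophenyl in place of 4-(trifluoromethyl)phenyl on a carbonyl carbon.

Two measured steps start from compound 1 and touch this very position. Replacing the whole aryl group by a methyl gave a 1.8-fold lower number from compound 1 to compound 2 (0.26 log units; within the scatter), and replacing only the trifluoromethyl by a methyl on the aromatic ring gave a 2.4-fold lower number from compound 1 to compound 3 (0.38 log units; beyond the scatter). Both changes moved the number downward, but only one of them beyond the scatter, so the ester appears to matter little for inhibition of these cells. For compound 4, a change from an aryl group to a different aryl group, a small downward move is therefore expected, most likely a 1.6-fold lower number from compound 1 to compound 4 (0.20 log units; within the scatter), which may well stay within the scatter.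

The estimate for compound 4 is 2000 nM, expected to lie between 900 nM and 4500 nM.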

Compound 4, half-maximal inhibitory concentration: 390 nM
For compound 4 the middle estimate is 5.1-fold (0.71 log units) above the measured one; measured number outside the range, below it.
By their numbers in this assay, from the lowest: compound 4; then compounds 3, 2 and 1 (each within the scatter of the next, the first and the last beyond it).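

In this assay, among these compounds, this ester position proves more responsive than the earlier compounds suggested: the change to 2-chlorophenyl gives an 8.1-fold lower number from compound 1 to compound 4 (0.91 log units; beyond the scatter) and is the largest step seen at this carbonyl carbon. Compound 4 also stands apart from the other two esters, with a 3.4-fold lower number from compound 3 to compound 4 (0.53 log units; beyond the scatter) and a 4.5-fold lower number from compound 2 to compound 4 (0.65 log units; beyond the scatter) as well, so its lead does not depend on which earlier ester serves as the comparison. Compounds 1 and 3 also carry an aromatic ring here, so the presence of a ring alone does not account for the lower number of compound 4; what the ring carries, or where it carries it, makes the difference.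

The group on the ring and its place on the ring change together from compound 1 to compound 4, so their shares stay unresolved, and a 4-chlorophenyl or a 2-(trifluoromethyl)phenyl ester would help to separate them. Going by these compounds, how a ring bearing an amine or a carboxylic acid would behave at this position also remains open. Nothing available here explains why this ester gives the lowest number.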